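A few compounds are considered here, and "the series" means these few. Any claim that something is new, unique, unknown or untested is made for them only; others in the source may bear on it.

Compound 1 `CC(c1ccc(N(C)C)c(Cl)c1)N(Cc1ccc(C(C)(C)C)cc1)Cc1cc2cc(C3CC3)ccc2[nH]c1=O`: in a toxicity assay on MDCK cells (Canis lupus familiaris) for cytotoxicity, read by crystal violet staining, with a stated time of 48 h (a higher number here means that more compound is tolerated, a lower number that less compound is tolerated), compound 1 gives > 10000 nM, a limit of the assay.
Compound 2 `CC(c1ccc(OC(F)(F)F)c(Cl)c1)N(Cc1ccc(C(C)(C)C)cc1)Cc1cc2cc(C3CC3)ccc2[nH]c1=O`: in this assay compound 2 gives > 10000 nM, likewise a limit.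

Compound 1 therefore stands at the limit of > 10000 nM in this assay, at which 2 of the 2 values shown sit, so only a range is known for it. Compound 3 `CC(C)(C)c1ccc(CN(Cc2ccc(C(F)(F)F)c(Cl)c2)Cc2cc3cc(C4CC4)ccc3[nH]c2=O)cc1` differs from compound 1 by 3-chloro-4-(trifluoromethyl)benzyl in place of 1-(3-chloro-4-(dimethylamino)phenyl)ethyl on an amine nitrogen. Among the compounds with values here, the only measured step, a step that the two limits leave unreadable from compound 1 to compound 2, is unreadable, and it swaps a smaller group than the change to compound 3, so no measured step truly covers this change. Compound 3 is expected to remain at the limit as well, an expected step that the limit leaves unreadable from compound 1 to compound 3. Compound 3 is estimated at 15000 nM, between 7000 nM and 40000 nM.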

Compound 3, half-maximal cytotoxic concentration: > 10000 nM
Compound 3 ended at the assay's limit (the forecaster's own chance of this, stated with the estimate: 85%); the middle value lies beyond the limit too.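

In this assay no step can be read between compound 1 and compound 3, since both sit at a limit, as does compound 2: the limit of > 10000 nM in this assay, at which 3 of the 3 values shown sit.

The compounds shown leave open whether any of these changes alters how much compound the cells tolerate.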